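Bringing a hydroxyl back onto the hydrazone aryl group

The source may hold more compounds than are shown below. What is called first, only, known or untested is meant among the compounds shown, and "the series" means these compounds.

Compound 1 `CCCSc1nc(N/N=C(\C)c2ccc(O)cc2)c2nnn(Cc3ccccc3)c2n1` in a functional assay on MGC-803 cells (Homo sapiens) for antiproliferative activity, read by MTT assay, with a stated time of 72 h (on this read-out higher numbers stand for weaker inhibition and lower numbers for stronger inhibition), gives 16700 nM. Compound 2 `C#CCSc1nc(N/N=C/c2ccc(N(C)C)cc2)c2nnn(Cc3ccccc3)c2n1` in this assay gives 7620 nM. Compound 3 `CCCSc1nc(N/N=C/c2ccc(Cl)cc2)c2nnn(Cc3ccccc3)c2n1` in this assay reaches only a limit, > 64000 nM.

Compound 3 therefore stands at the weak end of what has been seen so far: its value is a limit of the assay rather than a number, and it sits at the limit of > 64000 nM in this assay, at which 1 of the 3 values shown sits. For the measured compounds named here, the one measured step that leads to it, an at least 3.8-fold higher number from compound 1 to compound 3 (0.58 log units; beyond the scatter), shows that exchanging the hydroxy-bearing aryl group of compound 1 for a chlorophenyl group pushed the number up beyond the scatter.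

Compound 4 `CCCSc1nc(N/N=C/c2c(O)ccc3ccccc23)c2nnn(Cc3ccccc3)c2n1` is not yet measured. It differs from compound 3 in one place: 2-hydroxynaphthalen-1-yl in place of 4-chlorophenyl on a carbon with a double bond to nitrogen. A hydroxyl thus returns to the aromatic part on the hydrazone carbon, and a second fused ring arrives with it. The step of an at least 3.8-fold higher number from compound 1 to compound 3 (0.58 log units; beyond the scatter) is the only measured one that bears on this change, and it ran the other way; compound 4 is accordingly expected to show a lower number than compound 3. Compound 3 offers only a limit, which leaves the size of that drop open.

Compound 4 is expected to come in at about 20000 nM, with a likely range from 6000 nM to 70000 nM. That expectation amounts to a step of an at least 3.2-fold lower number from compound 3 to compound 4 (0.50 log units; beyond the scatter).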

Compound 4, half-maximal inhibitory concentration: 3710 nM
For compound 4 the middle estimate is 5.4-fold (0.73 log units) above the measured one, outside the stated range (below it).
By their numbers in this assay, from the lowest: compound 4; then compound 2; then compound 1. At a limit, above all of these: compound 3.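

With the rest of the molecule unchanged, 2-hydroxynaphthalen-1-yl in place of 4-chlorophenyl on a carbon with a double bond to nitrogen gives an at least 17-fold lower number from compound 3 to compound 4 (1.23 log units; beyond the scatter) in this assay, so the aryl group at this position alone can move the read-out by a large amount. The earlier step, an at least 3.8-fold higher number from compound 1 to compound 3 (0.58 log units; beyond the scatter), changed the aryl group and also removed the methyl on that same carbon, so it could not show what the aryl group does by itself. Compound 3 is held at a limit of the assay and not at a number, so the true size of the new step remains unknown: the limit of > 64000 nM in this assay, at which 1 of the 4 values shown sits.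

The new group brings a hydroxyl and a second fused ring together, and the compounds shown cannot tell which of the two accounts for the drop; a naphthalen-1-yl without the hydroxyl and a 2-hydroxyphenyl would pull them apart, and a methoxy in place of the hydroxyl would test the hydroxyl further. On these data alone, it also remains open whether 2-hydroxynaphthalen-1-yl has the same effect alongside the alkyne-bearing chain on the sulfur of compound 2.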